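The source may report more compounds than this note shows. Statements on the series, on what has been measured and on what is new or still open speak of the compounds shown alone.

In an ADME assay (liver) for metabolic stability, with Liver microsome (Rattus norvegicus) as the target, using microsomes (a lower number here means slower removal, a higher number faster removal of the compound), compound 1 `CN(C(=O)c1ccc2ncsc2c1)c1ccc(OCB2C=Cc3ccccc3N2)cc1` gives 73.3 mL/min/kg, compound 2 `CN(C(=O)c1ccc2ncsc2c1)c1ccc(OCc2ccc3ccccc3c2)cc1` gives 48.3 mL/min/kg, and compound 3 `CN(C(=O)c1cc(-c2ccccn2)n[nH]1)c1ccc(OCc2ccc3ccccc3n2)cc1` gives 35 mL/min/kg. Compound 2 has the second highest of these three numbers, and its gap to each of the others lies within the scatter. Compound 4 `CN(C(=O)c1csc(-c2cccnc2)n1)c1ccc(OCc2ccc3ccccc3c2)cc1` differs from compound 2 by 2-(pyridin-3-yl)-1,3-thiazol-4-yl in place of 1,3-benzothiazol-6-yl on a carbonyl carbon. Among the measured compounds shown here, the one measured single-point step, a 1.5-fold lower number from compound 1 to compound 2 (0.18 log units; within the scatter), concerns the group on the oxygen-bound chain carbon rather than the carbonyl side, so it does not bear directly on this change; compound 2 and compound 3, which differ in two places, show values within the scatter of each other. A step no larger than the scatter is therefore expected, the estimated step being a 1.1-fold lower number from compound 2 to compound 4 (0.03 log units; within the scatter). Compound 4 is expected to give 45 mL/min/kg, within 25 mL/min/kg to 80 mL/min/kg.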

Compound 4, clearance: > 283 mL/min/kg
Compound 4: no number, only a limit; the forecaster's own chance of this, stated with the estimate: 3%; middle value at least 6.2-fold (0.79 log units) from the limit.
By their numbers in this assay, from the lowest: compounds 3, 2 and 1 (each within the scatter of the next, the first and the last beyond it). At a limit, above all of these: compound 4.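

In this assay, the group on the carbonyl carbon proves able to move this number a long way: 2-(pyridin-3-yl)-1,3-thiazol-4-yl in place of 1,3-benzothiazol-6-yl gives an at least 5.8-fold higher number from compound 2 to compound 4 (0.76 log units; beyond the scatter). The earlier compounds shown here offered no single-place step at this position. The reading for compound 4 is a limit, not a number: the limit of > 283 mL/min/kg in this assay, at which 1 of the 4 values shown sits.

As far as these compounds go, how far the true step extends stays open. So does which part of the entering group matters, and a methyl group or a carboxylic acid in place of its pyridin-3-yl part would help separate that part from the thiazole ring.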